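From Compound 2 to Compound 3: One Aryl Group Replaced

The source may report more compounds than this note shows. Statements on the series, on what has been measured and on what is new or still open speak of the compounds shown alone.

Compound 2 (`COc1cc(/C=C2\CN(S(=O)(=O)c3ccc(NC(C)=O)cc3)C/C(=C\c3cc(OC)c(OC)c(OC)c3)C2=O)cc(OC)c1OC`) gives 3470 nM in a functional assay on SMMC-7721 cells (Homo sapiens) for cytotoxicity, read by MTT assay, with a stated time of 24 h (on this read-out higher numbers stand for weaker inhibition and lower numbers for stronger inhibition), and sits level with compound 1 (`COc1cc(/C=C2\CN(S(=O)(=O)c3ccc(F)cc3)C/C(=C\c3cc(OC)c(OC)c(OC)c3)C2=O)cc(OC)c1OC`), which gives 3840 nM there. For the measured compounds named here, the only measured step between them is a 1.1-fold lower number from compound 1 to compound 2 (0.04 log units; within the scatter) and comes from acetamido in place of fluoro on an aromatic carbon. Compound 3 (`COc1cc(/C=C2\CN(S(=O)(=O)c3ccc(NC(C)=O)cc3)C/C(=C\c3ccccc3F)C2=O)cc(OC)c1OC`) keeps that acetamido group and changes another part of compound 2: 2-fluorophenyl in place of 3,4,5-trimethoxyphenyl on a double-bonded chain carbon bound to a double-bonded ring carbon. In words, this is 2-fluorophenyl in place of 3,4,5-trimethoxyphenyl on a double-bonded chain carbon bound to a double-bonded ring carbon. Going by the values given here, no measured step covers this swap, so the data give no direction for it, and the one small step offers only weak guidance. The expected change is a 1.2-fold lower number from compound 2 to compound 3 (0.09 log units; within the scatter) and stays within the scatter. For compound 3 the estimated value is 2800 nM, with an expected range from 800 nM to 9500 nM.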

Compound 3, half-maximal inhibitory concentration: 3920 nM
Estimate against measurement, compound 3: 1.4-fold (0.15 log units) below, within the range that was stated.
By their numbers in this assay, from the lowest: compounds 2, 1 and 3 (each within the scatter of the next).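

In this assay, the change from 3,4,5-trimethoxyphenyl to 2-fluorophenyl on a double-bonded chain carbon bound to a double-bonded ring carbon produces a 1.1-fold higher number from compound 2 to compound 3 (0.05 log units; within the scatter) and leaves the read-out level. The earlier step exchanged only a single substituent on an aromatic carbon, whereas this one replaces a whole aryl group, removing its methoxy groups and adding a fluorine, and still no difference beyond the scatter appears. Nothing measured here explains why the numbers stay level.

This single pair cannot show whether the same holds for other aryl groups, such as unsubstituted phenyl or 4-methoxyphenyl. It also leaves open whether this place would accept a group of another kind, such as an amine, a carboxylic acid or a longer alkyl chain.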